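The compounds below may be only part of what the source reports. "The series", "measured", "known", "first", "only" and "open" are said of these compounds alone.

Measured so far:
- compound 1 `O=C(c1ccccc1)c1sc(N2CCCC2)nc1Br`: > 100000 nM (a limit)
- compound 2 `O=C(c1ccccc1)c1sc(N2CCCCC2)nc1Br`: 78000 nM
- compound 3 `COC(=O)c1sc2nc(N3CCCC3)sc2c1C`: 89000 nM

All three were tested in a functional assay on U-373MG ATCC cells (Homo sapiens) for cytotoxicity, read by MTT assay, with a stated time of 72 h; on this read-out lower numbers stand for stronger inhibition and higher numbers for weaker inhibition. For compound 1 the result is a limit of the assay rather than a number (the limit of > 100000 nM in this assay, at which 1 of the 3 values shown sits). Compound 2 carries the change piperidin-1-yl in place of pyrrolidin-1-yl on an aromatic carbon relative to compound 1, and the step is an at least 1.2-fold lower number from compound 1 to compound 2 (0.10 log units; that floor lies within the scatter). Compound 3 has a different core, and the difference between the two cores is not broken down here; compound 3 gives 89000 nM in this assay, close to compound 2.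

Compound 4 `COC(=O)c1sc2nc(N3CCCCC3)sc2c1C` is not yet measured. Relative to compound 3 it carries piperidin-1-yl in place of pyrrolidin-1-yl on an aromatic carbon. This is the same kind of change as that from compound 1 to compound 2, but the place differs: here the aromatic carbon sits in a ring that is part of a fused or bridged system of two rings, whereas in compound 1 it is two ring bonds from the ring atom that bears a bromo group and two ring bonds from the ring atom that bears a group of 8 heavy atoms.

The expected step is a 1.3-fold lower number from compound 3 to compound 4 (0.10 log units; within the scatter), resting on the earlier step of an at least 1.2-fold lower number from compound 1 to compound 2 (0.10 log units; that floor lies within the scatter), which was small. Compound 4 is therefore expected to give about 70000 nM, with a likely range from 30000 nM to 150000 nM.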

Compound 4, half-maximal inhibitory concentration: > 100000 nM
Compound 4: a limit, no number; the forecaster's own chance of this, stated with the estimate: 25%; middle value at least 1.4-fold (0.15 log units) from the limit.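

In this assay compound 4 gives > 100000 nM, a limit of the assay and not a number: the limit of > 100000 nM in this assay, at which 2 of the 4 values shown sit. On these data alone, the change to piperidin-1-yl therefore reads only as an at least 1.1-fold higher number from compound 3 to compound 4 (0.05 log units; that floor lies within the scatter), so no lowering of the number is seen on this core and the true size of the step remains unknown. Both steps for this change are bounded on one side only, so the data show neither that it carries from one core to the other nor that it does not: the same change on two cores in this assay, an at least 1.2-fold lower number (0.10 log units; that floor lies within the scatter) from compound 1 to compound 2 and an at least 1.1-fold higher number (0.05 log units; that floor lies within the scatter) from compound 3 to compound 4; the limit leaves it open whether they differ.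

The compounds shown leave open whether a different amine at this place, such as morpholine or an open-chain dimethylamine, would give a clearly lower number on either core. Also open, as far as these compounds go, is whether a carboxylic acid or an amide in place of the methyl ester on the core of compound 3 would change the read-out at all.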